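The compounds below may be only part of what the source reports. "The series", "measured", "known", "first", "only" and "open" are said of these compounds alone.

Compounds measured so far:
compound 1 `CN(C)S(=O)(=O)NC[C@@H]1CCCc2cc(S(=O)(=O)c3cccc(F)c3)ccc21`, 2 nM in an assay on isolated protein for displacement of a labelled ligand from 5-hydroxytryptamine receptor 6 (Homo sapiens); a higher number here means a weaker inhibitor, a lower number a stronger inhibitor
compound 2 `O=C1CN=C(NC[C@@H]2CCCc3cc(S(=O)(=O)c4cccc(F)c4)ccc32)N1`, 0.1 nM in this assay

Compound 2 gives the lowest of the two numbers in this assay; its nearest neighbour is compound 1, and the step of a 20-fold lower number from compound 1 to compound 2 (1.30 log units; beyond the scatter) separates them, well beyond the scatter. Compound 3 `O=C(NC[C@@H]1CCCc2cc(S(=O)(=O)c3cccc(F)c3)ccc21)c1ccc[nH]1` is not yet measured in this assay. It differs from compound 2 in one place: a group of 7 heavy atoms (5 carbon, 1 nitrogen, 1 oxygen; one five-membered aromatic ring with 1 hetero atom) in place of a group of 6 heavy atoms (3 carbon, 2 nitrogen, 1 oxygen; one five-membered non-aromatic ring with 2 hetero atoms), on an amine nitrogen. Among the measured compounds shown here, the only measured step that bears on this change is a 20-fold lower number from compound 1 to compound 2 (1.30 log units; beyond the scatter), which shows that what sits on this amine nitrogen moves the number a great deal. For the measured compounds named here, there is no measured compound carrying the (1H-pyrrol-2-yl)carbonyl group, so the direction can only be judged from the fact that compound 2 already gives the lowest number seen. Compound 3 is therefore expected to give a higher number than compound 2, by a step of about a 20-fold higher number from compound 2 to compound 3 (1.30 log units; beyond the scatter), likely beyond the scatter. The estimate for compound 3 in this assay is 2 nM, with a range from 0.4 nM to 10 nM.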

Compound 3, inhibition constant: 5.01 nM
Estimate against measurement, compound 3: 2.5-fold (0.40 log units) below, and the stated range covers the measured number.
By their numbers in this assay, from the lowest: compound 2; then compound 1; then compound 3.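

In this assay, swapping the five-membered non-aromatic ring with two hetero atoms for the (1H-pyrrol-2-yl)carbonyl group on the amine nitrogen gives a 50-fold higher number from compound 2 to compound 3 (1.70 log units; beyond the scatter), so the very low number of compound 2 does not carry over to this second ring-bearing group. Set against dimethylsulfamoyl, the same group gives a 2.5-fold higher number from compound 1 to compound 3 (0.40 log units; beyond the scatter), a modest step that shows that, of the three groups seen at this position, only the one in compound 2 reaches so low a number, while the other two stay much closer to each other. Both the group that leaves and the group that enters count one hydrogen-bond donor, so that count alone does not separate them, and nothing measured here accounts for the difference between these groups.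

The compounds leave open which part of the group in compound 2 matters, since a plain guanidine or an open-chain urea on the same amine nitrogen would separate the ring from its nitrogen atoms and carbonyl. As far as these compounds go, it is also open whether an imidazole-2-carbonyl or a simple acetyl group would lie nearer to compound 2 or to compound 3.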